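Compound 2 to compound 4: ethoxy to 1-methylethenyl

The compounds below may be only part of what the source reports. "The series", "measured", "known", "first", "only" and "open" are said of these compounds alone.

Measured so far in a functional assay on HEL cells (Homo sapiens) (on this read-out higher numbers stand for lower toxicity in this test and lower numbers for higher toxicity in this test), on these lines:
compound 1 (`Cc1cn([C@@H]2O[C@H](CO[Si](C)(C)C(C)(C)C)[C@@]3(OS(=O)(=O)C=C3NCC(=O)O)[C@H]2O[Si](C)(C)C(C)(C)C)c(=O)n(C)c1=O`) gives 136000 nM
compound 2 (`CCOC(=O)NC(=O)NC1=CS(=O)(=O)O[C@@]12[C@@H](CO[Si](C)(C)C(C)(C)C)O[C@@H](n1cc(C)c(=O)n(C)c1=O)[C@@H]2O[Si](C)(C)C(C)(C)C`) gives 14000 nM
compound 3 (`Cc1cn([C@@H]2O[C@@H]3COC(=O)[C@]3(OS(C)(=O)=O)[C@H]2O)c(=O)[nH]c1=O`) gives >= 36000 nM (a limit)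

Compound 3 gives >= 36000 nM as a limit and not as a number. Compound 2 at 14000 nM holds the lower of the two actual numbers in this assay and compound 1 the higher.

Compound 4 (`C=C(C)C(=O)NC(=O)NC1=CS(=O)(=O)O[C@@]12[C@@H](CO[Si](C)(C)C(C)(C)C)O[C@@H](n1cc(C)c(=O)n(C)c1=O)[C@@H]2O[Si](C)(C)C(C)(C)C`) is still unmeasured. Within the data shown here, its single change from compound 2 is 1-methylethenyl in place of ethoxy on a carbonyl carbon, counted as 1-methylethenyl in place of ethoxy on a carbonyl carbon and leaving the rest of the structure as it stands.

Among the measured compounds shown here, one measured step bears on this part of the structure: a 9.7-fold lower number from compound 1 to compound 2 (0.99 log units; beyond the scatter) when (ethoxycarbonyl)carbamoyl replaced carboxymethyl on an amine nitrogen. For the measured compounds named here, no measured step isolates ethoxy itself. Compound 4 alters only part of what entered in a 9.7-fold lower number from compound 1 to compound 2 (0.99 log units; beyond the scatter) and so a smaller step is expected, with no firm direction and probably none beyond the scatter. The estimated change is a 1.3-fold lower number from compound 2 to compound 4 (0.10 log units; within the scatter) in this read-out. For compound 4 the estimate is 11000 nM with an expected range from 4000 nM to 32000 nM in this assay once it is measured.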

Compound 4, half-maximal cytotoxic concentration: 1200 nM
Compound 4: middle estimate off by 9.2-fold (0.96 log units), on the high side; the measured number lies below the stated range.
By their numbers in this assay, from the lowest: compound 4; then compound 2; then compound 1.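

In this assay, the group on the carbonyl carbon makes a large difference on its own: with the rest of the structure unchanged, 1-methylethenyl in place of ethoxy gives a 12-fold lower number from compound 2 to compound 4 (1.07 log units; beyond the scatter). The earlier step, a 9.7-fold lower number from compound 1 to compound 2 (0.99 log units; beyond the scatter), exchanged the whole of carboxymethyl for (ethoxycarbonyl)carbamoyl on an amine nitrogen and could not show what the end of that group contributes, whereas ((1-methylethenyl)carbonyl)carbamoyl in place of carboxymethyl now gives a 110-fold lower number from compound 1 to compound 4 (2.05 log units; beyond the scatter), so the end group counts as well as the carbamoyl unit. No measurement shown gives a reason for the step from ethoxy to 1-methylethenyl.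

On these data alone, it remains open whether the lower number follows from gaining the double bond of 1-methylethenyl or from losing the oxygen of ethoxy, and an isopropyl group or an amine on the same carbonyl carbon would help to separate the two. As far as these compounds go, it also remains open whether the step carries over to a core without the two silyl ether groups, for example one with free hydroxyl groups in their place.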